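Swapping a methyl for a chloro on the aromatic ring

The source may report more compounds than this note shows. Statements on the series, on what has been measured and on what is new or still open speak of the compounds shown alone.

Of the compounds shown here, three have so far been measured in a physicochemical assay for lipophilicity; a higher number here means a more lipophilic compound, a lower number a more polar compound. Compound 1, with the structure `CNC(=O)c1cc(C(=O)N[C@H]2CC[C@H](O)CC2)c([C@@H](C)c2cccc(C)c2)o1`, gives 3.3 in this assay. Compound 3, with the structure `CNC(=O)c1cc(C(=O)NC2CC2)cn([C@@H](C)c2ccccc2)c1=O`, gives 3.3, which is level with compound 1 at the digits shown. Compound 2, with the structure `CC[C@@H](c1ccccc1)n1nc(C(=O)NC)cc1C(=O)N[C@H]1[C@@H]2C[C@H](O)C[C@@H]21`, gives 3.6, a reading that sits within the usual scatter of the value for compound 1, so no separation between these three can be claimed from the numbers alone.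

The next compound, compound 4, has the structure `CNC(=O)c1cc(C(=O)N[C@H]2CC[C@H](O)CC2)c([C@@H](C)c2cccc(Cl)c2)o1` and has not yet been measured in this assay. It differs from compound 1 in one place only: chloro in place of methyl on an aromatic carbon.

Among the compounds with values here, no step of this kind between two measured compounds is available here, so the expectation rests on the change itself. Compound 4 is expected to show a small step upward from compound 1, one that stays within the scatter, namely a number 0.20 log units higher from compound 1 to compound 4 (within the scatter). The estimate for compound 4 in this assay is 3.5, with a range from 3.1 to 3.9.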

Compound 4, distribution coefficient: 3.5
The estimate for compound 4 equals the measured number at the digits printed; the range from low to high includes it.
By their numbers in this assay, from the lowest: compounds 1, 3, 4 and 2 (each within the scatter of the next).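

The earlier compounds shown here differ from one another in more than one place, so none of them isolated a single change. Compound 4 does: on the shared core, going from 3-methylphenyl to 3-chlorophenyl in this assay gives a number 0.20 log units higher from compound 1 to compound 4 (within the scatter) and so leaves the two groups hard to tell apart by this measurement at this position on the aromatic ring. Nothing measured here speaks to what lies behind this result.

As far as these compounds go, it remains open how a methoxy group or an amine at this same place would read in this assay and whether any group there would give a step beyond the scatter. Also open, from the compounds shown here alone, is whether the same swap would give a similar step on the different cores of compound 2 and compound 3.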